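This account rests on a few compounds, and the source may have more. Where it says the series, first, only, none or still open, it means among the compounds named here.

Going by the values given here, in an assay on isolated protein for inhibition of serine/threonine-protein kinase D2 (Homo sapiens), read by mobility shift assay, tested at 30 uM (a higher number here means more inhibition at the concentration tested (going by the name of the read-out), a lower number less inhibition), compound 1 `Cc1cc2[nH]nc(N)c2c(=O)[nH]1` gives -1%, the second highest of the three numbers measured so far. Compound 2 `Nc1n[nH]c2cc(-c3cccs3)[nH]c(=O)c12` gives 5%, and the step of a number 6 percentage points higher from compound 1 to compound 2 (within the scatter) lies within the scatter. Compound 3 `CC(C)(C)c1cc2[nH]nc(N)c2c(=O)[nH]1` gives -15%, the step of a number 14 percentage points lower from compound 1 to compound 3 (beyond the scatter) being beyond the scatter yet modest. Compound 4 `Cc1cc2[nH]ncc2c(=O)[nH]1` differs from compound 1 by hydrogen in place of amino on an aromatic carbon. Among the compounds with values here, none of the measured steps touches this amino group; all three alter a different aromatic carbon, and none moved the read-out far from zero. There is thus no basis for expecting a step beyond the scatter in this assay for compound 4. Compound 4 is expected to give 0%, somewhere between -15% and 15%, which would be an estimated step of a number 1 percentage points higher from compound 1 to compound 4 (within the scatter).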

Compound 4, a percentage reported as inhibition, at one concentration (the size of the read-out at that concentration, not a potency): -30%
Compound 4: middle estimate off by 30 percentage points, on the high side; measured number outside the range, below it.
By their numbers in this assay, from the lowest: compound 4; then compound 3; then compounds 1 and 2 (each within the scatter of the next).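

In this assay, going by these compounds alone, hydrogen in place of amino gives a number 29 percentage points lower from compound 1 to compound 4 (beyond the scatter), so this position, untouched by the earlier steps, can also move the number beyond the scatter. Within the data shown here, both numbers are negative, so the step does not show a loss of real inhibition, only that the amino group matters to the read-out. Nothing available explains the shift. Open, going by these compounds, is what a methylamino or acetamido group would do at this position. Also open, on these data alone, is whether the step would hold alongside thiophen-2-yl or tert-butyl in place of methyl.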